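Swapping an Aminopropyl Chain for Chloro on the Quinoline Core

A few compounds are considered here, and "the series" means these few. Any claim that something is new, unique, unknown or untested is made for them only; others in the source may bear on it.

Of the compounds shown here, two have been tested so far in a functional assay on DLD-1 cells (Homo sapiens) for cytotoxicity, read by MTT assay, with a stated time of 48 h; a higher number here means a weaker inhibitor, a lower number a stronger inhibitor. Compound 1 `Clc1ccnc2cc(OCc3ccccc3)ccc12` carries a chloro on its shared core and gives 3270 nM. Compound 2 `CN(C)CCCNc1ccnc2cc(OCc3ccc(F)cc3)ccc12` carries a (3-(dimethylamino)propyl)amino group at that position and a fluorine on its benzyloxy ring, and in this assay compound 2 gives 2540 nM. Compound 2 holds the lowest of the two numbers, but the gap to compound 1 lies within the usual scatter, so the two cannot be ranked against each other.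

Compound 3 `Fc1ccc(COc2ccc3c(Cl)ccnc3c2)cc1` has not yet been measured. It is reached from compound 2 by one change: chloro in place of (3-(dimethylamino)propyl)amino on an aromatic carbon. Going by the values given here, the only comparison at hand is compound 1, which also bears a chloro there and gives 3270 nM in this assay, a number that sits close to that of compound 2. On that basis the step from compound 2 to compound 3 is expected to be small, leaning toward a slightly higher number, and to stay within the scatter, as a 1.3-fold higher number from compound 2 to compound 3 (0.11 log units; within the scatter). Compound 3 is therefore estimated at 3300 nM, with a plausible range from 1500 nM to 7500 nM.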

Compound 3, half-maximal inhibitory concentration: 3230 nM
The estimate for compound 3 lay 1.0-fold (0.01 log units) above the measured number; measured number inside the range.
By their numbers in this assay, from the lowest: compounds 2, 3 and 1 (each within the scatter of the next).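

Going by these compounds alone, compound 3 allows the first direct comparison at this position, opposite the ring nitrogen, because compounds 2 and 3 differ only there. In this assay, replacing (3-(dimethylamino)propyl)amino with chloro gives a 1.3-fold higher number from compound 2 to compound 3 (0.10 log units; within the scatter), so this large difference in the group, which removes a chain with its hydrogen-bond donor and acceptors, leaves no readable change in the number. Compound 3 also pairs with compound 1, where fluoro in place of hydrogen on an aromatic carbon gives a 1.0-fold lower number from compound 1 to compound 3 (0.01 log units; within the scatter), so that change cannot be read as having an effect here either. Nothing measured here explains why these numbers stay so close.

From the compounds shown here alone, whether a different group at the same position would separate from these compounds remains open, for example a plain amine, a morpholine ring or a longer chain ending in a dimethylamino group. Also open, going by these compounds, is how (3-(dimethylamino)propyl)amino behaves with hydrogen in place of the fluorine, a pairing that would show whether the two changes act independently of each other.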